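The source may report more compounds than this note shows. Statements on the series, on what has been measured and on what is new or still open speak of the compounds shown alone.

Compounds measured in a functional assay on cells (Neutrophil, Homo sapiens) for inhibition, with a stated time of 10 min; a higher number here means a weaker inhibitor, a lower number a stronger inhibitor:

compound 1, `CCOC(=O)c1cnn(CC(C)O)c1NC(=O)Nc1ccc(F)cc1` — a limit, > 10 nM
compound 2, `CCOC(=O)c1cnn(CC(C)O)c1NC(=O)NCc1ccccc1` — 15 nM
compound 3, `CCCC(O)Cn1ncc(C(=O)OCC)c1NC(=O)NC(C)C` — 20 nM

Compound 2 gives the lowest of the two numbers in this assay. Its nearest neighbour is compound 3, whose value lies within the scatter of that of compound 2, so no order between the two can be stated. Compound 1 supplies only a limit (the limit of > 10 nM in this assay, at which 1 of the 3 values shown sits), and the step that the limit leaves unreadable from compound 1 to compound 2 is therefore not readable in size.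

The next compound is compound 4, `CCOC(=O)c1cnn(C)c1NC(=O)NCc1ccccc1`. It differs from compound 2 by hydrogen in place of 1-hydroxyethyl on a saturated chain carbon bound to an aromatic nitrogen; cut one bond further out, the same difference reads 2-hydroxypropyl to methyl.

Among the compounds with values here, none of the measured steps touches the chain on the aromatic nitrogen: the one readable comparison, between compound 2 and compound 3, changes both that chain and the urea substituent at once, and the two values sit within the scatter. No size or direction for the change to compound 4 can be drawn from the numbers shown.

With that in mind, compound 4 is expected to stay near compound 2, with the estimated step of a 2.0-fold higher number from compound 2 to compound 4 (0.30 log units; within the scatter) allowed to run either way. The estimate for compound 4 in this assay is 30 nM, within a range from 8 nM to 120 nM.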

Compound 4, half-maximal inhibitory concentration: 18 nM
For compound 4 the middle estimate is 1.7-fold (0.22 log units) above the measured one, and the stated range covers the measured number.
By their numbers in this assay, from the lowest: compounds 2, 4 and 3 (each within the scatter of the next).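

In this assay, within the data shown here, replacing 2-hydroxypropyl with methyl gives a 1.2-fold higher number from compound 2 to compound 4 (0.08 log units; within the scatter), and this is the first readable comparison that alters only the chain on the aromatic nitrogen. With the benzyl urea held constant, the 1-hydroxyethyl part can therefore be removed from the saturated chain carbon bound to the aromatic nitrogen without a change beyond the scatter, so this pair shows no need for that part to keep the value in this range. Nothing in the available evidence gives a reason for this result.

As far as these compounds go, only methyl and 2-hydroxypropyl are compared directly at this place, so it remains open whether a longer chain such as n-butyl, or a chain ending in an amine or a carboxylic acid, would leave the value similarly unmoved. From the compounds shown here alone, it is also open whether the same change would be as small with other urea substituents, as compound 1 supplies only a limit and compound 3 differs from the benzyl ureas in both the chain and the urea substituent.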